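The source may report more compounds than this note shows. Statements on the series, on what has been measured and on what is new or still open speak of the compounds shown alone.

Compound 1 `CC1(C)Cc2c(sc(NC(=O)c3cccnc3O)c2C(N)=O)C(C)(C)O1` gives 190 nM in an assay on cells for positive allosteric modulation of Cystic fibrosis transmembrane conductance regulator variant F508del (Homo sapiens), with stated times of 10 min and 7 s, in the presence of a further agent that is not named here; a lower number here means that less compound is needed, a higher number that more compound is needed for the effect.
Compound 2 `CC1(C)Cc2c(sc(NC(=O)c3nnc[nH]3)c2C(N)=O)C(C)(C)O1` gives 467 nM.
Compound 3 `CC1(C)Cc2c(sc(NC(=O)C3(O)CC3)c2C(N)=O)C(C)(C)O1` gives 23 nM.

Compound 3 has the lowest number of the three measured compounds: an 8.3-fold lower number from compound 1 to compound 3 (0.92 log units; beyond the scatter) and a 20-fold lower number from compound 2 to compound 3 (1.31 log units; beyond the scatter), both beyond the scatter. Compound 4 `CC1(C)Cc2c(sc(NC(=O)[C@H](O)C(C)(C)C)c2C(N)=O)C(C)(C)O1` carries 1-hydroxy-2,2-dimethylpropyl in place of 1-hydroxycyclopropyl on a carbonyl carbon. Among the compounds with values here, no measured step covers this exact swap. The two steps that end at compound 3 exchanged an aromatic ring for the hydroxycyclopropyl group and lowered the number, whereas here a group with no ring enters in its place, so those steps give only indirect guidance. The expectation is a step of a 2.0-fold higher number from compound 3 to compound 4 (0.29 log units; within the scatter), a modest rise that may still fall within the scatter. Compound 4 is therefore estimated at 45 nM, with a range from 15 nM to 150 nM.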

Compound 4, half-maximal effective concentration: 127 nM
For compound 4 the middle estimate is 2.8-fold (0.45 log units) below the measured one; low and high end bracket the measured number.
By their numbers in this assay, from the lowest: compound 3; then compounds 4 and 1 (each within the scatter of the next); then compound 2.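

In this assay, replacing 1-hydroxycyclopropyl on this carbonyl carbon with the ring-free 1-hydroxy-2,2-dimethylpropyl gives a 5.5-fold higher number from compound 3 to compound 4 (0.74 log units; beyond the scatter), so this hydroxyl-bearing group does not match the cyclopropyl one. The ring-free group still compares well with 4H-1,2,4-triazol-3-yl, with a 3.7-fold lower number from compound 2 to compound 4 (0.57 log units; beyond the scatter), and it cannot be told apart from 2-hydroxypyridin-3-yl, with a 1.5-fold lower number from compound 1 to compound 4 (0.17 log units; within the scatter). No measurement here explains these differences. Still open, on these data alone, is whether the ring or the size of the group matters more, which 1-hydroxycyclobutyl could help test. As far as these compounds go, the mirror-image form of compound 4 and an amine in place of the hydroxyl also remain open.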